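Reversing the Enone Chain on a Weakly Antiproliferative Scaffold

The compounds below may be only part of what the source reports. "The series", "measured", "known", "first", "only" and "open" are said of these compounds alone.

Among the measured compounds shown here, compound 2, `COc1ccc(/C=C/C(=O)c2cc(-c3ccc(OC)c(OC)c3)n3nc(-c4ccccc4)cc3n2)cc1`, is the only compound in this set with a numeric result. In an ADME assay on HEK293 cells (Homo sapiens) for antiproliferative activity, read by MTT assay, with a stated time of 24 h (on this read-out lower numbers stand for stronger inhibition and higher numbers for weaker inhibition), compound 2 gives 50700 nM. Compound 1, `COc1cc(C(=O)/C=C/c2cc(-c3cc(OC)c(OC)c(OC)c3)n3nc(-c4ccccc4)cc3n2)cc(OC)c1OC`, reaches only a limit of the assay, >= 100000 nM. For the measured compounds named here, the evidence amounts to the limit of >= 100000 nM in this assay, at which 1 of the 2 values shown sits, so no step between measured compounds can be read, and the two values show only that compound 2 has a number where compound 1 has a limit.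

Compound 3, `COc1ccc(-c2cc(/C=C/C(=O)c3ccc(C)c(C)c3)nc3cc(-c4ccccc4)nn23)cc1OC`, has not been measured. It differs from compound 2 by 2-((3,4-dimethylphenyl)carbonyl)ethenyl in place of (2-(4-methoxyphenyl)ethenyl)carbonyl on an aromatic carbon. The shared core and the 3,4-dimethoxyphenyl group are kept; the group names show the carbonyl and ethenyl in reversed sequence, and a 3,4-dimethylphenyl in place of a 4-methoxyphenyl. Going by the values given here, no measured pair in this set follows such a change, so nothing here sets a direction. The step from compound 2 to compound 3 in this assay is expected to remain within the scatter, a 1.0-fold lower number from compound 2 to compound 3 (0.01 log units; within the scatter). Compound 3 is therefore estimated at 50000 nM, between 15000 nM and 150000 nM, with a real chance that only a limit is reported.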

Compound 3, half-maximal inhibitory concentration: 46200 nM
Estimate against measurement, compound 3: 1.1-fold (0.03 log units) above; measured number inside the range.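

In this assay, this position on the aromatic carbon next to the ring nitrogen now has its first readable step: placing 2-((3,4-dimethylphenyl)carbonyl)ethenyl where (2-(4-methoxyphenyl)ethenyl)carbonyl stood gives a 1.1-fold lower number from compound 2 to compound 3 (0.04 log units; within the scatter). The exchange reverses the sequence of carbonyl and ethenyl and also replaces 4-methoxyphenyl with 3,4-dimethylphenyl, and the two compounds cannot be told apart on this read-out, so this combined change leaves the number unmoved beyond the scatter. Compound 1 still stands only at a limit of the assay, so no step to it can be read, and the set stays anchored to that limit: the limit of >= 100000 nM in this assay, at which 1 of the 3 values shown sits.

Among the compounds shown here, the single step cannot separate the reversal of the chain from the change of the terminal ring, and the two changes could offset each other. On these data alone, whether an amine or a carboxylic acid on that terminal ring, or a longer chain in place of the ethenyl link, would bring a number clearly apart from those of compound 2 and compound 3 remains open.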